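The source may hold more compounds than are shown below. What is called first, only, known or untested is meant among the compounds shown, and "the series" means these compounds.

Working notes on the series. Compound 1 `C[C@@H](NC(=O)Nc1ccc(C(C)(C)C)cc1)c1ccccc1` and compound 2 `C[C@H](NC(=O)Nc1ccc(C(C)(C)C)cc1)c1ccccc1` share all atoms and bonds and differ only in configuration as drawn. In an ADME assay on the whole organism with Oryza sativa as the target, tested at 0.1 uM (on this read-out higher numbers stand for a weaker effect at the one concentration tested and lower numbers for a stronger effect), compound 1 gives 100%, and in this assay compound 2 gives 100%. The step of no change at the digits printed from compound 1 to compound 2 (within the scatter) is attributed to the stereocentre alone because of the fact that compounds 1 and 2 differ only in the configuration as drawn. Going by the values given here, compound 3 `COc1ccccc1NC(=O)N[C@@H](C)c1ccccc1` gives 98% in this assay; no single step connects it to compound 2, and its number lies within the scatter of that of compound 2. Compound 2 therefore stands level with compound 1 and close to compound 3, so the three numbers sit together near the top of the scale.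

Compound 4 `CC(=O)c1ccc(NC(=O)N[C@@H](C)c2ccccc2)cc1` is the next candidate: acetyl in place of tert-butyl on an aromatic carbon. Among the compounds with values here, the only measured step, no change at the digits printed from compound 1 to compound 2 (within the scatter), does not touch the tert-butyl, and no measured step exchanges a substituent on that aromatic carbon, so it bears only weakly on this change. The expectation for this assay is a step of a number 3 percentage points lower from compound 2 to compound 4 (within the scatter), nothing beyond the scatter. Compound 4 is accordingly estimated at 97%, with a range from 85% to 100%.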

Compound 4, a percentage reported as activity, at one concentration (the size of the read-out at that concentration, not a potency): 99%
Compound 4: middle estimate off by 2 percentage points, on the low side; the range from low to high includes it.
By their numbers in this assay, from the lowest: compounds 3, 4, 1 and 2 (each within the scatter of the next).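

In this assay, going by these compounds alone, acetyl in place of tert-butyl on an aromatic carbon para to a large group gives a number 1 percentage points lower from compound 2 to compound 4 (within the scatter), the first measured step that exchanges a substituent at this position. The exchange removes a group of 4 heavy atoms with 0 hydrogen-bond acceptors and introduces one of 3 heavy atoms with 1 hydrogen-bond acceptor and a double bond outside the aromatic ring, yet the two numbers remain level within the scatter. No available evidence bears on the reason for this result.

The compounds shown leave open whether an amine or a carboxylic acid on this aromatic carbon would also remain level with tert-butyl and acetyl. They also leave open whether any substituent at this position can move the number beyond the scatter.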